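Same halophenyl swap carried onto a second linker

A few compounds are considered here, and "the series" means these few. Any claim that something is new, unique, unknown or untested is made for them only; others in the source may bear on it.

Three compounds have numbers in a functional assay on A-431 cells (Homo sapiens) for antiproliferative activity, read by MTT assay, with a stated time of 72 h; on this read-out higher numbers stand for weaker inhibition and lower numbers for stronger inhibition. Compound 1 `COc1cc2ncnc(Nc3cccc(Cl)c3F)c2cc1OCCCCC(=O)Nc1ccc(S(N)(=O)=O)cc1` gives 5560 nM. Compound 2 `COc1cc2ncnc(Nc3ccc(C(F)(F)F)cc3)c2cc1OCCCCC(=O)Nc1ccc(S(N)(=O)=O)cc1` gives 16900 nM. Compound 3 `NS(=O)(=O)c1ccc(NC(=S)Nc2ccc3ncnc(Nc4ccc(C(F)(F)F)cc4)c3c2)cc1` gives 18000 nM. The numbers for compound 2 and compound 3 lie within the scatter of each other, so nothing is said about their order; compound 1 sits apart from both by more than the scatter.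

Compound 1 and compound 2 differ in one place: 3-chloro-2-fluorophenyl in place of 4-(trifluoromethyl)phenyl on a nitrogen on an aromatic ring. This gave a 3.0-fold lower number from compound 2 to compound 1 (0.48 log units; beyond the scatter).

Compound 4 `NS(=O)(=O)c1ccc(NC(=S)Nc2ccc3ncnc(Nc4cccc(Cl)c4F)c3c2)cc1` is the same change made on compound 3: 3-chloro-2-fluorophenyl in place of 4-(trifluoromethyl)phenyl on a nitrogen on an aromatic ring. The place is described in the same words for both pairs, so the change is the same, not merely of the same kind. The difference between the core of compound 3 and the core of compound 2 is not broken down here.

Among the compounds with values here, only one measured example of the change exists, so the expectation rests on a single step. Within the data shown here, for compound 4 the step of a 2.8-fold lower number from compound 3 to compound 4 (0.44 log units; beyond the scatter) is expected to be of about the same size as the earlier one, because a 3.0-fold lower number from compound 2 to compound 1 (0.48 log units; beyond the scatter) is the only guide available for this change. Compound 4 is therefore estimated at 6500 nM in this assay. The expected range for compound 4 runs from 2500 nM to 16000 nM; it is wide since the change has been seen once only and on a different core.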

Compound 4, half-maximal inhibitory concentration: 13100 nM
Beside the measured number, compound 4's estimate is 2.0-fold (0.30 log units) below it, within the range that was stated.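

In this assay, the change from 4-(trifluoromethyl)phenyl to 3-chloro-2-fluorophenyl on the core of compound 3 gives a 1.4-fold lower number from compound 3 to compound 4 (0.14 log units; within the scatter), so on this core the change does not separate the two compounds. The step on the first core lies beyond the scatter and the one on the second core within it, yet the two steps cannot be told apart in size: the same change on two cores in this assay, a 3.0-fold lower number (0.48 log units; beyond the scatter) from compound 2 to compound 1 and a 1.4-fold lower number (0.14 log units; within the scatter) from compound 3 to compound 4, 2.2-fold (0.34 log units) apart, within the scatter of two such steps

Within the data shown here, the two pairs therefore give no evidence that the core alters the effect of this change, but they also do not show that the effect carries over at a fixed size, since each core supplies only one pair and the result rests on a single aryl exchange in a single cell assay.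

Still open, on these data alone, is whether the same pattern holds for other groups on that nitrogen, such as a plain phenyl or a phenyl bearing a nitrile, and on cores beyond these two. Also open, as far as these compounds go, is how the numbers respond to changes elsewhere, such as a longer chain in the linker of compound 1 or a carboxylic acid in place of the sulfonamide.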